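Stereochemical inversion of a cyclobutane TRPV3 antagonist

The source may hold more compounds than are shown below. What is called first, only, known or untested is meant among the compounds shown, and "the series" means these compounds.

Measured compounds:
compound 1 `C[C@]1(O)C[C@](c2ccc(OC(F)(F)F)cc2)([C@H](O)c2ccccn2)C1`: 1510 nM
compound 2 `C[C@]1(O)C[C@](c2ccc(C(F)(F)F)cc2)([C@H](O)c2ccccn2)C1`: 4790 nM

Within the data shown here, in an assay on HEK293 cells for antagonist activity at transient receptor potential cation channel subfamily V member 3 (Homo sapiens), read by FLIPR and calcium flux (on this read-out lower numbers stand for stronger inhibition and higher numbers for weaker inhibition), compound 1 gives 1510 nM, the lowest of the two numbers, with compound 2 next at 4790 nM; the only measured step, a 3.2-fold higher number from compound 1 to compound 2 (0.50 log units; beyond the scatter), concerns a substituent swap on the aromatic ring, not configuration. Compound 3 `C[C@]1(O)C[C@@](c2ccc(OC(F)(F)F)cc2)([C@@H](O)c2ccccn2)C1` differs from compound 1 in this way: the two compounds have the same atoms and bonds and differ only in configuration as drawn: 2 of 3 stereo elements differ; a stereocentre at a saturated ring carbon is drawn r in compound 1 and s in compound 3; a stereocentre at a saturated chain carbon is drawn S in compound 1 and R in compound 3. Among the measured compounds shown here, no measured pair shows what inverting stereocentres does to this assay here, so the step expected for compound 3, estimated as a 2.3-fold higher number from compound 1 to compound 3 (0.37 log units; beyond the scatter), rests on no measured analogue and is no more than a guess. Stereoisomers of this kind can be equally active or much weaker. A modest weakening is estimated, with wide uncertainty, so compound 3 is expected to give 3500 nM, between 600 nM and 25000 nM.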

Compound 3, antagonist equilibrium constant: > 10400 nM
Compound 3: only a limit was reported (the forecaster's own chance of this, stated with the estimate: 15%); middle value at least 2.9-fold (0.47 log units) away from the limit.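

Inverting a stereocentre at a saturated ring carbon and another at a saturated chain carbon gives an at least 6.8-fold higher number from compound 1 to compound 3 (0.83 log units; beyond the scatter) in this assay, the first measured sign that configuration matters in this series. Compound 3 gives > 10400 nM, which is a limit of the assay and not a number. With no atom or bond changed, the weakening can be traced to configuration alone because of this: the fact that compounds 1 and 3 differ only in the configuration as drawn

The two stereocentres changed together, so the compounds shown leave open whether one of them alone accounts for the step, and whether the trifluoromethyl compound 2 would respond to the same inversion in the same way. As far as these compounds go, it also remains open how either configuration would fare with an amine or a carboxylic acid added to the shared core.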